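This account rests on a few compounds, and the source may have more. Where it says the series, first, only, none or still open, it means among the compounds named here.

Working notes on the series, step from compound 3 to compound 4.

Three compounds have numbers in an assay on isolated protein for inhibition of coagulation factor X (Oryctolagus cuniculus), tested at 1 uM; a higher number here means more inhibition at the concentration tested (going by the name of the read-out), a lower number less inhibition. Compound 1 `O=C1[C@@H](NS(=O)(=O)c2cc3ccc(Cl)nc3s2)CCN1Cc1cc2cc[nH]cc-2n1` gives 50%. Compound 2 `O=C1[C@@H](NS(=O)(=O)c2cc3cccnc3s2)CCN1Cc1cc2c[nH]ccc-2n1` gives 18%. Compound 3 `O=C1[C@@H](NS(=O)(=O)c2nc3cc(Cl)ccc3[nH]2)CCN1Cc1cc2c[nH]ccc-2n1` gives 31%. Compound 3 therefore stands second of the three: its number is beyond the scatter above compound 2 and beyond the scatter below compound 1.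

For the measured compounds named here, the one step measured so far on the sulfonyl sulfur, a number 13 percentage points higher from compound 2 to compound 3 (beyond the scatter), is modest. Compound 4 `O=C1[C@@H](NS(=O)(=O)c2cc3ccc(Cl)nc3s2)CCN1Cc1cc2c[nH]ccc-2n1` reverses that direction and adds a chlorine: a group of 10 heavy atoms (7 carbon, 1 nitrogen, 1 sulfur, 1 chlorine; one five-membered aromatic ring with 1 hetero atom, one six-membered aromatic ring with 1 hetero atom) in place of a group of 10 heavy atoms (7 carbon, 2 nitrogen, 1 chlorine; one five-membered aromatic ring with 2 hetero atoms, one six-membered aromatic ring of carbon only), on a sulfonyl sulfur. Going by the values given here, compound 4 thus carries the same sulfonyl group as compound 1 on the core shared with compound 2 and compound 3; the two cores are isomers, and no step between them has been measured, so the reading of compound 1 can only be taken as a hint, not a step.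

The bearing of compound 2 would argue for a drop back toward its number; the bearing of compound 1 argues for a number near the top of the range seen. Weighing both, a modest rise is expected, a number 9 percentage points higher from compound 3 to compound 4 (within the scatter), so compound 4 is estimated at 40% in this assay, between 25% and 55%.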

Compound 4, a percentage reported as inhibition, at one concentration (the size of the read-out at that concentration, not a potency): 51%
For compound 4 the middle estimate is 11 percentage points below the measured one; the measured number falls inside the stated range.
By their numbers in this assay, from the lowest: compound 2; then compound 3; then compounds 1 and 4 (each within the scatter of the next).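

In this assay, for the compounds shown here, chloro in place of hydrogen on an aromatic carbon, the one change between these two compounds, gives a number 33 percentage points higher from compound 2 to compound 4 (beyond the scatter), so the chlorine on this group on the sulfonyl sulfur matters far more than the earlier compounds could show. With a chlorine present on both groups, replacing 5-chloro-1H-benzimidazol-2-yl on the sulfonyl sulfur gives a number 20 percentage points higher from compound 3 to compound 4 (beyond the scatter), so the earlier rise from compound 2 to compound 3, which mixed a ring change with an added chlorine, cannot be read as showing that the number is higher with the benzimidazole. Exchanging one isomeric core for the other, with this sulfonyl group held constant, gives a number 1 percentage points higher from compound 1 to compound 4 (within the scatter), so the two cores are not told apart in this assay with this group in place.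

As far as these compounds go, whether the step is particular to chloro stays open, as fluoro, bromo, methyl or methoxy on the same aromatic carbon would be needed to test it. Whether the two cores also match with the unchlorinated group remains equally open, and nothing on hand accounts for any of these steps.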